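Phenyl to 4-methylphenyl: the step from compound 2 to compound 3

The source may hold more compounds than are shown below. What is called first, only, known or untested is meant among the compounds shown, and "the series" means these compounds.

In a functional assay on K562 cells (Homo sapiens) for inhibition, read by sulforhodamine B assay, with a stated time of 48 h (on this read-out lower numbers stand for stronger inhibition of growth and higher numbers for weaker inhibition of growth), compound 2 `CC(C)(C)NCc1c(C(=O)O)nn(-c2ccccc2)c1-c1ccccc1` gives > 716000 nM, which is a limit and not a number. Compound 1 `CC(C)(C)NCc1c(C(=O)O)nn(-c2ccccc2)c1-c1ccc(F)cc1` gives > 680000 nM, which is also a limit. Among the measured compounds shown here, compound 2 therefore has no numerical place, and the only other value is no firmer.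

Compound 3 `Cc1ccc(-c2c(CNC(C)(C)C)c(C(=O)O)nn2-c2ccccc2)cc1` has methyl in place of hydrogen on an aromatic carbon, para to a large group: methyl in place of hydrogen on an aromatic carbon.

For the measured compounds named here, only one measured step bears on this change: a step that the two limits leave unreadable from compound 1 to compound 2, with hydrogen in place of fluoro on an aromatic carbon. It gives no size to carry over. No step beyond the scatter is expected in this assay, and another limit is the likeliest report.

The step expected is an at least 1.0-fold lower number from compound 2 to compound 3 (0.01 log units; that floor lies within the scatter). Compound 3 is estimated at 690000 nM, with an expected range of 300000 nM to 900000 nM.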

Compound 3, concentration for 50% growth inhibition: > 688000 nM
Compound 3: only a limit was reported (the forecaster's own chance of this, stated with the estimate: 85%); the middle value does not contradict the limit.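

Compound 3 gives only a limit, > 688000 nM, so its steps from compound 1 and from compound 2 cannot be read. Going by these compounds, with compound 1, compound 2 and compound 3 all reported as limits, it remains open whether fluoro, hydrogen or methyl at this place makes any difference in this assay.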